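Methyl for chloro on a thiosemicarbazone series

The compounds below may be only part of what the source reports. "The series", "measured", "known", "first", "only" and "open" are said of these compounds alone.

In a functional assay on MOLT-4 cells (Homo sapiens), with a stated time of 72 h (a higher number here means a weaker inhibitor, a lower number a stronger inhibitor), compound 3 `O=C1/C(=N\NC(=S)Nc2ccc(Cl)cc2)c2cc(Br)ccc2N1Cc1ccc(F)cc1` gives 48000 nM and stands highest of the three measured compounds. Compound 1 `Cc1ccc(NC(=S)N/N=C2\C(=O)Nc3ccc(Br)cc32)cc1` gives 4900 nM, and compound 2 `Cc1ccc(NC(=S)N/N=C2\C(=O)N(Cc3ccc(F)cc3)c3ccc(F)cc32)cc1` gives 1500 nM in this assay; both gaps to compound 3 lie beyond the scatter. Compound 4 `Cc1ccc(NC(=S)N/N=C2\C(=O)N(Cc3ccc(F)cc3)c3ccc(Br)cc32)cc1` has not yet been measured. It differs from compound 3 in one place: methyl in place of chloro on an aromatic carbon. Both compounds carrying the methyl group, compound 1 with 4900 nM and compound 2 with 1500 nM, sit well below compound 3, so the step of a 12-fold lower number from compound 3 to compound 4 (1.08 log units; beyond the scatter) is expected to be a clear decrease beyond the scatter. Compound 4 is therefore estimated at 4000 nM, with a range from 1000 nM to 16000 nM.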

Compound 4, half-maximal inhibitory concentration: 57000 nM
For compound 4 the middle estimate is 14-fold (1.15 log units) below the measured one, outside the stated range (above it).
By their numbers in this assay, from the lowest: compound 2; then compound 1; then compounds 3 and 4 (each within the scatter of the next).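

In this assay, 4-chlorophenyl and 4-methylphenyl cannot be told apart on this background (a 1.2-fold higher number from compound 3 to compound 4 (0.07 log units; within the scatter)), so the methyl group does not by itself bring the lower numbers seen for the other methyl compounds. The large differences instead lie at other places: bromo in place of fluoro on an aromatic carbon (a 38-fold higher number from compound 2 to compound 4 (1.58 log units; beyond the scatter)) and 4-fluorobenzyl in place of hydrogen on the ring nitrogen (a 12-fold higher number from compound 1 to compound 4 (1.07 log units; beyond the scatter)). Nothing given here explains either large step. As far as these compounds go, whether chloro and methyl also match when fluoro replaces bromo remains open, as does how an amine or a carboxylic acid would read at this position.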